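From 4-hydroxyphenyl to 3-chloro-4-hydroxyphenyl: working notes

The source may report more compounds than this note shows. Statements on the series, on what has been measured and on what is new or still open speak of the compounds shown alone.

Of the compounds shown here, two have numbers so far in a functional assay on HT-1080 cells (Homo sapiens) for cytotoxicity, read by MTT assay, with a stated time of 72 h; a lower number here means a stronger inhibitor, a higher number a weaker inhibitor. Compound 1 (`COc1ccc(/C=C2\CCC/C(=C\c3ccccc3Br)C2=O)cc1OC`) gives 8400 nM, and compound 2 (`COc1ccc(/C=C2\CCC/C(=C\c3ccc(O)cc3)C2=O)cc1OC`) gives 16800 nM. Going by the values given here, compound 2 therefore has the higher of only two numbers, but the two values lie within the scatter of each other, so neither can be ranked.

Compound 3 (`COc1ccc(/C=C2\CCC/C(=C\c3ccc(O)c(Cl)c3)C2=O)cc1OC`) keeps the core of compound 2 and differs in one place: chloro in place of hydrogen on an aromatic carbon. This is chloro in place of hydrogen on an aromatic carbon, ortho to a hydroxy group and meta to a large group.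

Among the compounds with values here, no measured step covers this exchange directly. Within the data shown here, the only guide is a 2.0-fold higher number from compound 1 to compound 2 (0.30 log units; within the scatter), where 4-hydroxyphenyl replaces 2-bromophenyl and the difference stays within the scatter. One step is thin evidence, but it gives no ground for expecting a shift in either direction beyond the scatter in this assay. The expected step is a 1.4-fold lower number from compound 2 to compound 3 (0.15 log units; within the scatter). For compound 3 the estimated value is 12000 nM, with an expected range of 5000 nM to 28000 nM.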

Compound 3, half-maximal inhibitory concentration: 7600 nM
Compound 3: the middle estimate sits 1.6-fold (0.20 log units) above what was measured; low and high end bracket the measured number.
By their numbers in this assay, from the lowest: compounds 3, 1 and 2 (each within the scatter of the next, the first and the last beyond it).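

In this assay, going by these compounds alone, chloro in place of hydrogen on an aromatic carbon, ortho to a hydroxy group and meta to a large group, gives the only step in these compounds that lies beyond the scatter: a 2.2-fold lower number from compound 2 to compound 3 (0.34 log units; beyond the scatter), a modest step that rests on a single pair. This position on the 4-hydroxyphenyl group therefore responds to a single added chlorine atom, whereas the earlier exchange of whole groups stayed within the scatter. The 3-chloro-4-hydroxyphenyl group still cannot be separated from the 2-bromophenyl group, with a 1.1-fold lower number from compound 1 to compound 3 (0.04 log units; within the scatter), and no measurement here bears on the reason for the step from hydrogen to chloro.

The compounds shown leave open whether the step depends on the hydroxy group, which a 3-chlorophenyl group would address directly. Also open, as far as these compounds go, is whether bromo, methyl, methoxy or an amine on the same aromatic carbon would give a step of similar size, or whether the step seen with chloro is particular to that group.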